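From pyrrolidin-2-yl to phenyl on the carbonyl carbon

The source may hold more compounds than are shown below. What is called first, only, known or untested is meant among the compounds shown, and "the series" means these compounds.

In a functional assay (strain AB) with Danio rerio as the target, read by microscopy, with a stated time of 1 h (a higher number here means that more compound is needed for the effect, a lower number that less compound is needed), compound 3 `CCN1CCc2c(sc(NC(=O)[C@@H]3CCCN3)c2C(N)=O)C1` reads > 25000 nM as a limit of the assay and not as a number. Compound 1 `CCN1CCc2c(sc(NC(=O)NCC3CCCO3)c2C(N)=O)C1` reads > 25000 nM as the same kind of limit. Compound 3 thus stands at the limit of > 25000 nM in this assay, at which 2 of the 3 values shown sit, without a readable number. Going by the values given here, compound 2 `CCN1CCc2c(sc(NC(=O)Nc3cccc(C)c3)c2C(N)=O)C1` gives 13000 nM and is the only member with a number so far.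

The move to compound 4 `CCN1CCc2c(sc(NC(=O)c3ccccc3)c2C(N)=O)C1` is phenyl in place of pyrrolidin-2-yl on a carbonyl carbon and amounts to phenyl in place of pyrrolidin-2-yl on a carbonyl carbon. Among the measured compounds only compound 2 carries an aromatic ring of carbon only, as its 3-methylphenyl. Among the compounds with values here, the steps that bear on this are an at least 1.9-fold lower number from compound 1 to compound 2 (0.28 log units; that floor lies within the scatter) and an at least 1.9-fold higher number from compound 2 to compound 3 (0.28 log units; that floor lies within the scatter) and neither is large. The remaining step is a step that the two limits leave unreadable from compound 1 to compound 3 and adds nothing.

Compound 2 with 13000 nM is the nearest guide, so a small move to a lower number is expected in this assay and it may not clear the scatter. Another reading at the limit remains possible. The expected step is an at least 1.5-fold lower number from compound 3 to compound 4 (0.19 log units; that floor lies within the scatter) in this estimate. For compound 4 the estimated value is 16000 nM with an expected range from 7000 nM to 25000 nM on repeat measurement.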

Compound 4, half-maximal effective concentration: > 25000 nM
Compound 4 ended at the assay's limit; the forecaster's own chance of this, stated with the estimate: 40%; middle value at least 1.5-fold (0.19 log units) away from the limit.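

Compound 4 shows that an aromatic ring of carbon only on the carbonyl carbon is not enough by itself to bring a reading off the limit in this assay, so that ring alone does not account for the number seen for compound 2. Phenyl in place of (3-methylphenyl)amino on a carbonyl carbon gives an at least 1.9-fold higher number from compound 2 to compound 4 (0.28 log units; that floor lies within the scatter), so this position has still produced no step shown to lie beyond the scatter, and the steps to compound 4 from compound 1 and from compound 3 cannot be read. The position now reads mostly as a limit and not as a ranking of groups: the limit of > 25000 nM in this assay, at which 3 of the 4 values shown sit.

As far as these compounds go, compound 4 removes the amide-type nitrogen and the methyl of compound 2 in one change, so the share of each in the number for compound 2 stays open. Also open, from the compounds shown here alone, is how phenylamino without the methyl, or a benzyl group, would read on the same carbonyl carbon, and whether any group there gives a step clearly beyond the scatter.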